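The compounds below may be only part of what the source reports. "The series", "measured", "known", "first", "only" and "open" are said of these compounds alone.

Antiproliferative read-out, as inhibition, in a functional assay on BGC-823 cells (Homo sapiens) for antiproliferative activity, read by MTT assay, tested at 1 uM; on this read-out higher numbers stand for a stronger effect at the one concentration tested and lower numbers for a weaker effect:

- compound 1 `COc1cc(C2=NN(C(C)=O)C(c3ccc(F)c(F)c3)O2)cc(OC)c1OC`: 18.3%
- compound 2 `COc1cc(C(=O)N/N=C/c2cccc(C(F)(F)F)c2)cc(OC)c1OC`: 17.7%
- compound 3 `COc1cc(C(=O)N/N=C/c2ccc(Cl)c([N+](=O)[O-])c2)cc(OC)c1OC`: -5.8%

Compound 1 stands highest of the three numbers. Compound 2 sits within the scatter of compound 1, so the two cannot be ordered. Compound 3 lies beyond the scatter below compound 1, the only gap in this set that counts as real.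

Compound 4 `COc1cc(C2=NN(C(C)=O)C(c3ccc(Cl)c(Cl)c3)O2)cc(OC)c1OC` is not yet measured. It differs from compound 1 in one place: 3,4-dichlorophenyl in place of 3,4-difluorophenyl on a saturated ring carbon. Among the compounds with values here, no measured pair shows this change, so the size of the step is unknown; the expectation is for no step beyond the scatter, in either direction. Compound 4 is expected to give about 21% in this assay , between 6% and 38%, an expected step of a number 2.7 percentage points higher from compound 1 to compound 4 (within the scatter).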

Compound 4, a percentage reported as inhibition, at one concentration (the size of the read-out at that concentration, not a potency): -0.8%
Compound 4: middle estimate off by 21.8 percentage points, on the high side; measured number below the stated range.
By their numbers in this assay, from the lowest: compounds 3 and 4 (each within the scatter of the next); then compounds 2 and 1 (each within the scatter of the next).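

In this assay, within the data shown here, the 3,4-difluorophenyl on the saturated ring carbon cannot be exchanged freely: 3,4-dichlorophenyl in its place gives a number 19.1 percentage points lower from compound 1 to compound 4 (beyond the scatter), the only single-change step so far. The read-out at this position therefore responds to the identity of the two halogens on the phenyl ring, though this rests on one pair. Nothing measured here accounts for the step.

Whether any halogen is needed remains open, since unsubstituted phenyl at this carbon falls outside the compounds shown. The same holds for methoxy on that phenyl ring, or for a longer chain in place of the acetyl group.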